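Aryl amide variation and cytotoxicity in the series

The compounds below may be only part of what the source reports. "The series", "measured", "known", "first", "only" and "open" are said of these compounds alone.

Three compounds share one core and differ only in the aryl group on the carbonyl carbon. Compound 1 `Cc1ccc(C(=O)Nc2cc(Cl)ccc2OCC(=O)Nc2ccc(S(N)(=O)=O)cc2C)cc1` gives 54200 nM in a functional assay on C8166 cells (Homo sapiens) for cytotoxicity, read by MTT assay; on this read-out higher numbers stand for lower toxicity in this test and lower numbers for higher toxicity in this test. Compound 2 `Cc1cc(S(N)(=O)=O)ccc1NC(=O)COc1ccc(Cl)cc1NC(=O)c1cccc([N+](=O)[O-])c1` gives 58800 nM in this assay, and compound 3 `Cc1cc(S(N)(=O)=O)ccc1NC(=O)COc1ccc(Cl)cc1NC(=O)c1cc(Cl)ccc1Cl` gives 42100 nM. Compound 1 holds the second highest of the three numbers; nearest is the step of a 1.1-fold higher number from compound 1 to compound 2 (0.04 log units; within the scatter), furthest the step of a 1.3-fold lower number from compound 1 to compound 3 (0.11 log units; within the scatter). The remaining step, a 1.4-fold lower number from compound 2 to compound 3 (0.15 log units; within the scatter), is also within the scatter, so no aryl replacement on this carbonyl carbon has so far moved the read-out beyond the scatter.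

Compound 4 `Cc1cc(S(N)(=O)=O)ccc1NC(=O)COc1ccc(Cl)cc1NC(=O)c1ccc(Cl)c(Cl)c1` is not yet measured. It differs from compound 1 by 3,4-dichlorophenyl in place of 4-methylphenyl on a carbonyl carbon. The same kind of exchange on the same carbonyl carbon underlies the steps to compound 2 and compound 3, each within the scatter, so in this assay no step beyond the scatter is expected in either direction. Compound 4 is therefore expected to give 48000 nM, within 28000 nM to 85000 nM. This amounts to an expected 1.1-fold lower number from compound 1 to compound 4 (0.05 log units; within the scatter).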

Compound 4, half-maximal cytotoxic concentration: 158000 nM
Beside the measured number, compound 4's estimate is 3.3-fold (0.52 log units) below it, outside the stated range (above it).
By their numbers in this assay, from the lowest: compounds 3, 1 and 2 (each within the scatter of the next); then compound 4.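

On this carbonyl carbon, the aryl group can move the read-out in this assay beyond the scatter: 3,4-dichlorophenyl gives a 2.9-fold higher number from compound 1 to compound 4 (0.46 log units; beyond the scatter) and a 2.7-fold higher number from compound 2 to compound 4 (0.43 log units; beyond the scatter) in modest steps, both toward lower toxicity in this test. Exchanging one dichlorophenyl for another gives a 3.8-fold higher number from compound 3 to compound 4 (0.57 log units; beyond the scatter) and is also modest, so the presence of a dichlorophenyl group does not alone set the number, and compound 3 goes against any such reading. Nothing measured here accounts for this shift.

From the compounds shown here alone, it remains open whether a single chlorine is enough, as 3-chlorophenyl or 4-chlorophenyl on the same carbonyl carbon would show. Also open, going by these compounds, is whether the higher number persists with 3,4-dimethoxyphenyl or with a non-aromatic cyclohexyl group in this place.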